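Swapping Methyl for Chloro on the Sulfonamide Ring

The source may report more compounds than this note shows. Statements on the series, on what has been measured and on what is new or still open speak of the compounds shown alone.

Compound 1, `Cc1ccc(S(=O)(=O)NCc2cn(C[C@H](O)[C@H]3OC(=O)C(OCc4ccccc4)=C3OCc3ccccc3)nn2)cc1`, carries a sulfonamide on its triazole arm and a pair of benzyloxy groups on the shared core. In a functional assay on SW-620 cells (Homo sapiens) for antiproliferative activity, read by MTT assay, with a stated time of 72 h (a lower number here means a stronger inhibitor, a higher number a weaker inhibitor), compound 1 gives 45800 nM. Two related compounds were tested alongside it. Compound 2, `O=C1O/C(=C\Cn2cc(-c3ccc(Br)cc3)nn2)C(OCc2ccccc2)=C1OCc1ccccc1`, reaches only a limit in this assay, > 100000 nM, which marks the edge of what the assay reports rather than a number. Compound 3, `O=C1O/C(=C\Cn2cc(-c3cc(C(F)(F)F)cc(C(F)(F)F)c3)nn2)C(OCc2ccccc2)=C1OCc1ccccc1`, likewise gives only a limit, > 100000 nM. Among the measured compounds shown here, compound 1 therefore stands as the only compound of the three with a measured figure, and the two others sit at the limit of > 100000 nM in this assay, at which 2 of the 3 values shown sit.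

Compound 4, `O=C1O[C@H]([C@@H](O)Cn2cc(CNS(=O)(=O)c3ccc(Cl)cc3)nn2)C(OCc2ccccc2)=C1OCc1ccccc1`, differs from compound 1 in a single place on the sulfonamide ring: chloro in place of methyl on an aromatic carbon. Both groups are single heavy atoms, neither adds a hydrogen-bond donor or acceptor, and no ring is gained or lost. Without any measured pair showing what this swap does here, the expected step from compound 1 to compound 4 is a 1.1-fold lower number from compound 1 to compound 4 (0.04 log units; within the scatter), which is no more than the scatter of repeated measurements. Compound 4 is thus estimated at 42000 nM in this assay, with a likely range from 15000 nM to 100000 nM.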

Compound 4, half-maximal inhibitory concentration: 18000 nM
Beside the measured number, compound 4's estimate is 2.3-fold (0.37 log units) above it; the range from low to high includes it.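

Among the compounds shown here, the swap on the sulfonamide ring, on an aromatic carbon para to a large group, gives the first measured step in this assay: a 2.5-fold lower number from compound 1 to compound 4 (0.41 log units; beyond the scatter), modest in size but beyond the usual scatter. This shows that the position is not indifferent to what sits on it, since exchanging one heavy atom for another, with no ring, hydrogen-bond donor or acceptor gained or lost, is enough to move the number. Nothing shown here explains why chloro gives a lower number than methyl.

This single step cannot show whether the number follows any trend across groups at this position, such as a fluoro, a methoxy or an amino group, or simply a hydrogen. It also leaves open whether the same exchange of methyl for chloro would give a similar step on a sulfonamide arm attached to a different core.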